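This account rests on a few compounds, and the source may have more. Where it says the series, first, only, none or still open, it means among the compounds named here.

Working notes on the series

Three compounds of the shared core carry a measured value in an assay on CHO cells for agonist activity at Neuronal acetylcholine receptor; alpha3/alpha6/beta2/beta3 (Homo sapiens), read by FLIPR and calcium flux; a higher number here means a larger maximal response, a lower number a smaller maximal response. Compound 1 `O=C(C1CCCC1)N1CC2CC(C1)N2` gives 62% in this assay. Compound 2 `O=C(CC1C=CCC1)N1CC2CC(C1)N2` gives 47%. Compound 3 `O=C([C@H]1C[C@H]1F)N1CC2CC(C1)N2` gives 130%, which is the highest of the three numbers; the nearest, compound 1, sits beyond the scatter below it, and compound 2 sits further below still, also beyond the scatter. Going by the values given here, no pair of these measured compounds differs in one place only, so no single-point step is available within the measured set; the two three-membered-ring-free compounds simply show lower numbers than compound 3.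

The next compound follows from compound 3 by one change. Compound 4 `C[C@@H]1C[C@H]1C(=O)N1CC2CC(C1)N2` differs from compound 3 as follows: 2-methylcyclopropyl in place of 2-fluorocyclopropyl on a carbonyl carbon

Among the compounds with values here, no measured pair speaks directly to this exchange. With the shorter ring kept and only the substituent on it exchanged, the expectation is a step downward from compound 3 that may reach beyond the scatter but should stay well above the numbers of compound 1 and compound 2. The step expected from compound 3 to compound 4 in this assay is a number 35 percentage points lower from compound 3 to compound 4 (beyond the scatter). Compound 4 is thus estimated at 95% in this assay, with a range from 60% to 135%.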

Compound 4, largest response reached (Emax), in percent of the reference or control that the assay uses: 110%
The estimate for compound 4 lay 15 percentage points below the measured number; the measured number falls inside the stated range.
By their numbers in this assay, from the lowest: compound 2; then compound 1; then compound 4; then compound 3.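

In this assay, going by these compounds alone, the exchange of 2-fluorocyclopropyl for 2-methylcyclopropyl on a carbonyl carbon is a number 20 percentage points lower from compound 3 to compound 4 (beyond the scatter) and counts as a modest step, the first single-place step. The two groups have the same count of heavy atoms and both hold one three-membered ring of carbon only, so the step follows the exchange of fluorine for carbon on that ring, and compound 4 still gives 110% in this assay with no fluorine in the group. Nothing measured on these compounds offers an explanation for the size of this step.

Within the data shown here, open is how the plain cyclopropyl group, 2-chlorocyclopropyl or the longer 2-ethylcyclopropyl would stand against these two groups on the same carbonyl carbon, and so whether the order of fluorine and methyl reflects a trend or only this pair. Also open, on these data alone, is whether the step keeps its direction and size when the two defined stereocentres of the ring are set the other way, since both groups are known here in a single arrangement only.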